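Cytotoxicity in the benzyl series: from compound 2 to compound 3

The source may hold more compounds than are shown below. What is called first, only, known or untested is meant among the compounds shown, and "the series" means these compounds.

Measured so far in an ADME assay on MT4 cells (Homo sapiens) for cytotoxicity, read by MTT assay, with a stated time of 4 days; on this read-out lower numbers stand for higher toxicity in this test and higher numbers for lower toxicity in this test:
- compound 1 `CCOC(=O)c1cnc(N2CCN(Cc3cccc(C(F)(F)F)c3)CC2)nc1Oc1c(C)cc(-c2ccc(C#N)cc2)cc1C` gives > 125000 nM, a limit of the assay.
- compound 2 `CCOC(=O)c1cnc(N2CCN(Cc3ccccc3F)CC2)nc1Oc1c(C)cc(-c2ccc(C#N)cc2)cc1C` gives > 125000 nM, also a limit of the assay.

Compound 2 therefore stands only at a limit in this assay, with no number of its own. Among the measured compounds shown here, the one step measured so far, a step that the two limits leave unreadable from compound 1 to compound 2, cannot be read in size or direction, since both ends are limits; this is summed up by the limit of > 125000 nM in this assay, at which 2 of the 2 values shown sit.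

Compound 3 `CCOC(=O)c1cnc(N2CCN(Cc3ccc(C(=O)OC)cc3)CC2)nc1Oc1c(C)cc(-c2ccc(C#N)cc2)cc1C` differs from compound 2 in one place: 4-(methoxycarbonyl)phenyl in place of 2-fluorophenyl on a saturated chain carbon bound to an amine nitrogen in a ring. For the measured compounds named here, no measured step speaks to this change, and the only step is itself unreadable. The expectation for compound 3 in this assay is accordingly that no step beyond the scatter appears and that the read-out again ends at a limit; the step from compound 2 to compound 3 is estimated at a step that the limit leaves unreadable from compound 2 to compound 3. For compound 3 the estimate is 150000 nM, within a range from 50000 nM to 400000 nM.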

Compound 3, half-maximal cytotoxic concentration: > 125000 nM
Compound 3: no number, only a limit; the forecaster's own chance of this, stated with the estimate: 80%; the middle value does not contradict the limit.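

Compound 3 also ends at a limit, so no step among compound 1, compound 2 and compound 3 can be read in this assay: the limit of > 125000 nM in this assay, at which 3 of the 3 values shown sit.

The compounds shown leave open whether any benzyl group on the shared core gives a measurable number in this assay, and how these three benzyl groups would compare.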